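Swapping chloro for methyl on a fused aromatic core

The source may report more compounds than this note shows. Statements on the series, on what has been measured and on what is new or still open speak of the compounds shown alone.

Compound 1, `CS(=O)(=O)Nc1ccc(Cl)c2c1CCCC2c1c[nH]cn1`, gives 2880 nM in an assay on isolated protein for binding affinity to Alpha-1D adrenergic receptor (Rattus norvegicus), read by radioligand binding; a lower number here means a stronger inhibitor, a higher number a weaker inhibitor.
Compound 2, `CS(=O)(=O)Nc1cccc2c1OCCC2c1c[nH]cn1`, gives 1150 nM in this assay.
Compound 3, `CCS(=O)(=O)Nc1cccc2c1CCC2c1c[nH]cn1`, gives 977 nM in this assay.

Among these three measured compounds, compound 1 has the highest number, and so is the weakest binder of the set. The gaps to compound 2 and to compound 3 both lie beyond the usual scatter, so this standing is genuine rather than noise.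

Compound 4, `Cc1ccc(NS(C)(=O)=O)c2c1C(c1c[nH]cn1)CCC2`, is not yet measured. It differs from compound 1 in a single spot: methyl in place of chloro on an aromatic carbon. One small, uncharged group on an aromatic carbon is exchanged for another of the same heavy-atom count, with no change in hydrogen-bond donors or acceptors.

For the measured compounds named here, since no measured pair here isolates this exchange, there is no direct precedent to lean on. The expectation is a step of about no change beyond the scatter in this assay, perhaps leaning slightly toward a lower number: a 1.2-fold lower number from compound 1 to compound 4 (0.06 log units; within the scatter). Compound 4 is thus estimated at 2500 nM, with a range from 900 nM to 7000 nM.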

Compound 4, inhibition constant: 2690 nM
Beside the measured number, compound 4's estimate is 1.1-fold (0.03 log units) below it; the range from low to high includes it.
By their numbers in this assay, from the lowest: compounds 3 and 2 (each within the scatter of the next); then compounds 4 and 1 (each within the scatter of the next).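

Methyl in place of chloro on this aromatic carbon, para to a methanesulfonamido group, gives a 1.1-fold lower number from compound 1 to compound 4 (0.03 log units; within the scatter) in this assay. For the compounds shown here, this is the only pair here that differs in one place, and it shows that the two groups cannot be told apart at this position on the core of compound 1, a reading that compounds 2 and 3 could not give. Nothing available explains why the two groups read alike in this assay.

The compounds shown leave open whether a different group on this same carbon, such as methoxy, an amine or a carboxylic acid, would move the number beyond the scatter. They also leave open whether methyl and chloro would read alike on the cores of compound 2 and compound 3.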